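Notes on a fluoro addition: compound 4 from compound 1

The compounds below may be only part of what the source reports. "The series", "measured", "known", "first", "only" and "open" are said of these compounds alone.

Measured so far:
- compound 1 `Cc1cc(=O)n(-c2ccccc2C(F)(F)F)nc1C(=O)Nc1ccc(Oc2ncnc3ccsc23)cc1`: 5550 nM
- compound 2 `Cc1cc(=O)n(-c2ccc(F)cc2)nc1C(=O)Nc1ccc(Oc2ncnc3ccsc23)cc1`: 4400 nM
- compound 3 `Cc1cc(=O)n(-c2ccc(F)c(F)c2)nc1C(=O)Nc1ccc(Oc2ncnc3ccsc23)cc1`: 5550 nM

All three were read in a functional assay on MCF7 cells (Homo sapiens) for cytotoxicity, read by MTT assay, with a stated time of 72 h; on this read-out higher numbers stand for weaker inhibition and lower numbers for stronger inhibition. The three numbers sit close: a 1.3-fold lower number from compound 1 to compound 2 (0.10 log units; within the scatter), no change at the digits printed from compound 1 to compound 3 (within the scatter) and a 1.3-fold higher number from compound 2 to compound 3 (0.10 log units; within the scatter) are each within the scatter, so no order among compound 1, compound 2 and compound 3 can be claimed.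

Compound 4 `Cc1cc(=O)n(-c2ccccc2C(F)(F)F)nc1C(=O)Nc1ccc(Oc2ncnc3ccsc23)c(F)c1` is not yet measured. It differs from compound 1 by fluoro in place of hydrogen on an aromatic carbon. The same kind of change, from compound 2 to compound 3, is fluoro in place of hydrogen on an aromatic carbon; there it gave a 1.3-fold higher number from compound 2 to compound 3 (0.10 log units; within the scatter). The two cores differ by 2-(trifluoromethyl)phenyl in place of 4-fluorophenyl on an aromatic nitrogen. The surroundings of the change are not the same word for word: in compound 3 the new fluoro is ortho to a fluoro group (1 heavy atom) and meta to a large group, whereas in compound 4 it is ortho to a large group and meta to a large group. It is therefore the same kind of change, not the same.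

For compound 4 the step is expected to be small, a 1.0-fold lower number from compound 1 to compound 4 (0.00 log units; within the scatter), resting on the within-scatter result of a 1.3-fold higher number from compound 2 to compound 3 (0.10 log units; within the scatter). Compound 4 is estimated at 5500 nM, between 2800 nM and 11000 nM.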

Compound 4, half-maximal inhibitory concentration: 6020 nM
Estimate against measurement, compound 4: 1.1-fold (0.04 log units) below; the range from low to high includes it.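

In this assay, fluoro in place of hydrogen on an aromatic carbon gives a 1.1-fold higher number from compound 1 to compound 4 (0.04 log units; within the scatter). This step is too small to be told from the scatter. Set beside the earlier case, the two steps do not differ: the same change on two cores in this assay, a 1.3-fold higher number (0.10 log units; within the scatter) from compound 2 to compound 3 and a 1.1-fold higher number (0.04 log units; within the scatter) from compound 1 to compound 4, 1.2-fold (0.07 log units) apart, within the scatter of two such steps. This shows that the change stayed within the scatter on both cores, but it does not show that a real effect carries from one core to the other, as neither step can be told from zero, the new fluoro has different surroundings in the two pairs, and two pairs set no rule for the series.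

The compounds shown leave open whether another group on this aromatic carbon, such as an amine or a methoxy group, would give a step beyond the scatter. They also leave open whether a carboxylic acid or a longer chain in place of the substituted phenyl on the aromatic nitrogen would move the number at all.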